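Amine ring variation at the end of the propoxy chain

A few compounds are considered here, and "the series" means these few. Any claim that something is new, unique, unknown or untested is made for them only; others in the source may bear on it.

The shared core of compound 1 `CN1CCc2ccc(OCCCN3CCCCC3)cc2C1=O` carries a three-carbon chain from the aryl oxygen to a basic amine ring; in an assay on cerebellum for displacement of a labelled ligand from histamine H1 receptor (Cavia porcellus), read by scintillation counting, with a stated time of 60 min (on this read-out lower numbers stand for stronger inhibition and higher numbers for weaker inhibition), compound 1 gives 23 nM. Compound 2 `CC1CCCN1CCCOc1ccc2c(c1)C(=O)N(C)CC2` is the 2-methylpyrrolidin-1-yl analogue, and in this assay compound 2 gives 26 nM. The step of a 1.1-fold higher number from compound 1 to compound 2 (0.05 log units; within the scatter) shows that putting 2-methylpyrrolidin-1-yl in place of piperidin-1-yl on the chain carbon three bonds along from the oxygen on the aromatic ring leaves the number essentially unchanged. Going by the values given here, compound 2 thus stands at the higher of the two numbers so far, but its gap to compound 1 is within the scatter, so the two cannot be ranked.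

Compound 3 `CN1CCc2ccc(OCCCN3CCCC3)cc2C1=O` removes the ring methyl: hydrogen in place of methyl on a saturated ring carbon. Among the compounds with values here, the only measured step that touches this amine ring, a 1.1-fold higher number from compound 1 to compound 2 (0.05 log units; within the scatter), was within the scatter, and compound 3 lies between compound 1 and compound 2 in ring size and in substitution, so no step beyond the scatter is expected in this assay in either direction. The expected step is a 1.0-fold lower number from compound 2 to compound 3 (0.02 log units; within the scatter). Compound 3 is estimated at 25 nM, within 12 nM to 55 nM.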

Compound 3, inhibition constant: 39 nM
Compound 3: the middle estimate sits 1.6-fold (0.19 log units) below what was measured, within the range that was stated.
By their numbers in this assay, from the lowest: compounds 1, 2 and 3 (each within the scatter of the next).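

In this assay, hydrogen in place of methyl on a saturated ring carbon, next to the ring nitrogen, gives a 1.5-fold higher number from compound 2 to compound 3 (0.18 log units; within the scatter), and pyrrolidin-1-yl in place of piperidin-1-yl gives a 1.7-fold higher number from compound 1 to compound 3 (0.23 log units; within the scatter), with both steps within the scatter. Compound 3 thus gives separate readings of the methyl and of the ring size, two differences that the earlier step between compound 1 and compound 2 held together, and neither reading separates from the scatter. Piperidin-1-yl, 2-methylpyrrolidin-1-yl and pyrrolidin-1-yl at the end of the propoxy chain therefore cannot be ranked in this assay from these three compounds. No measurement at hand offers an explanation for these numbers.

Still open, from the compounds shown here alone, is whether a larger amine ring such as azepan-1-yl, an open-chain dimethylamino group or a longer chain between the aryl oxygen and the amine would stay within the scatter of these numbers. Also open, going by these compounds, is whether a methyl group on the piperidin-1-yl ring would read the same way as the methyl on the five-membered ring.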